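A Methoxy Group Added to a Biaryl Fatty Acid Receptor Agonist

The source may hold more compounds than are shown below. What is called first, only, known or untested is meant among the compounds shown, and "the series" means these compounds.

Compound 1 `Cc1cccc(C)c1-c1cccc(COc2ccc(SCC(=O)O)cc2)c1` and compound 2 `Cc1cccc(C)c1-c1cccc(COc2ccc(S(=O)(=O)CC(=O)O)cc2)c1` share one core and differ only in the sulfur-bearing side chain. In a functional assay on CHO cells for agonist activity at Free fatty acid receptor 1 (Homo sapiens), read by FLIPR and calcium flux (a lower number here means that less compound is needed, a higher number that more compound is needed for the effect), compound 1 gives 195 nM, and compound 2 gives 66.1 nM. The single measured step, a 3.0-fold lower number from compound 1 to compound 2 (0.47 log units; beyond the scatter), comes from placing (carboxymethyl)sulfonyl in place of (carboxymethyl)sulfanyl on an aromatic carbon, and it leaves compound 2 standing as the lower of the two numbers shown.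

Compound 3 `COc1cc(C)c(-c2cccc(COc3ccc(S(=O)(=O)CC(=O)O)cc3)c2)c(C)c1` differs from compound 2 on the 2,6-dimethylphenyl ring: methoxy in place of hydrogen on an aromatic carbon, at a carbon meta to two methyl groups and para to a large group. No measured step touches this ring, so nothing shown bears directly on the change; the step from compound 1 to compound 2 concerns the side chain instead. Lacking any precedent, the expected step is a 1.1-fold lower number from compound 2 to compound 3 (0.04 log units; within the scatter), that is, no movement beyond the usual scatter, with the range widened to reflect the uncertainty. Compound 3 is therefore estimated at 60 nM in this assay, within a likely range from 15 nM to 250 nM.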

Compound 3, half-maximal effective concentration: 57.5 nM
Compound 3: middle estimate off by 1.0-fold (0.02 log units), on the high side; the measured number falls inside the stated range.
By their numbers in this assay, from the lowest: compounds 3 and 2 (each within the scatter of the next); then compound 1.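

In this assay, putting methoxy in place of hydrogen on the 2,6-dimethylphenyl ring gives a 1.1-fold lower number from compound 2 to compound 3 (0.06 log units; within the scatter), so compound 2 and compound 3 cannot be told apart in this test. Among these compounds, this is the first reading on this ring, since the earlier step concerned only the sulfur-bearing side chain, and it shows that the carbon meta to two methyl groups and para to a large group can carry methoxy, with its two heavy atoms and one hydrogen-bond acceptor, without a shift beyond the scatter. Nothing available explains why the number holds at this position.

From the compounds shown here alone, a single methoxy cannot show how far this freedom extends, so it remains open whether a longer chain such as butoxy, an amine or a carboxylic acid on the same carbon would also leave the number within the scatter. Going by these compounds, it is also open whether methoxy at this position would behave the same way with the sulfanyl side chain of compound 1 in place of the sulfonyl side chain.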